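Shortening the chain on the ring nitrogen of compound 3

The source may hold more compounds than are shown below. What is called first, only, known or untested is meant among the compounds shown, and "the series" means these compounds.

Among the compounds with values here, compound 3 `CCCCn1ncc(OCc2nnc(-c3ccc(F)cc3)o2)c(Cl)c1=O` gives 161000 nM in a functional assay on the whole organism for inhibition, with Mythimna separata as the target, with a stated time of 5 days (on this read-out higher numbers stand for an effect only at larger amounts of compound and lower numbers for an effect already at smaller amounts), the only proper number among the three values shown. Compound 1 `CCCCn1ncc(OCc2nnc(-c3ccccc3)o2)c(Cl)c1=O` sits at the limit > 299000 nM in this assay. Compound 2 `CCn1ncc(OCc2nnc(-c3ccccc3)o2)c(Cl)c1=O` also sits at the limit > 299000 nM in this assay. The fluoro step an at least 1.8-fold lower number from compound 1 to compound 3 (0.26 log units; that floor lies within the scatter) turned a limit into a number. Compound 4 `CCn1ncc(OCc2nnc(-c3ccc(F)cc3)o2)c(Cl)c1=O` differs from compound 3 by hydrogen in place of ethyl on a saturated chain carbon, two bonds along the chain from an aromatic nitrogen. Within the data shown here, the only measured step of this kind is a step that the two limits leave unreadable from compound 1 to compound 2, which is unreadable because both values sit at the limit of > 299000 nM in this assay, at which 2 of the 3 values shown sit. So the direction of the step in this assay cannot be taken from the measured compounds, and compound 3 already lies close to that limit. Compound 4 is therefore expected at 250000 nM, between 80000 nM and 800000 nM, a step estimated as a 1.6-fold higher number from compound 3 to compound 4 (0.19 log units; within the scatter), with a real chance that only a limit is reported.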

Compound 4, half-maximal effective concentration: > 299000 nM
Compound 4 ended at the assay's limit; the forecaster's own chance of this, stated with the estimate: 55%; at least 1.1-fold (0.07 log units) between middle value and limit.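

In this assay, the change from butyl to ethyl now has a step with a readable floor, an at least 1.8-fold higher number from compound 3 to compound 4 (0.26 log units; that floor lies within the scatter), whereas the earlier pair of compounds with this change gave none. The true size of this step may exceed that floor, so the result gives its direction only as far as the printed floor allows. The steps between two limits still cannot be read, and compound 3, which carries both butyl and fluoro, remains the only compound of the four with a proper number: the limit of > 299000 nM in this assay, at which 3 of the 4 values shown sit.

The compounds shown leave open whether a longer chain than butyl, such as hexyl, would give a lower number than compound 3. They also leave open whether chloro or methoxy in place of fluoro would give a proper number with the ethyl chain.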